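This account rests on a few compounds, and the source may have more. Where it says the series, first, only, none or still open, it means among the compounds named here.

Compound 3, `CCn1c([C@@H](C)NS(=O)(=O)c2ccc(F)cc2)nc2ccc(C(F)(F)F)cc21`, has the lowest of the two numbers given in an ADME assay (liver) for metabolic stability, with Liver microsome (Homo sapiens) as the target, read by LC-MS, using microsomes and NADPH, with a stated time of 5 min, at 37 degrees C; a higher number here means faster removal of the compound, a lower number slower removal: compound 3 gives 26 mL.min-1.g-1. Compound 1, `CCn1c([C@@H](C)NS(=O)(=O)c2ccc(Cl)cc2)nc2cc(C#N)ccc21`, gives in this assay 71 mL.min-1.g-1, a number beyond the usual scatter from that of compound 3. Compound 2, `CCn1c([C@@H](C)NS(=O)(=O)c2ccc(Cl)cc2)nc2cccc(Cl)c21`, reaches in this assay only a limit, > 100 mL.min-1.g-1, and not a number. Compound 4, `CCCn1cc(S(=O)(=O)N[C@H](C)c2nc3ccc(C(F)(F)F)cc3n2CC)c(C)n1`, is not yet measured in this assay. It differs from compound 3 by a group of 9 heavy atoms (7 carbon, 2 nitrogen; one five-membered aromatic ring with 2 hetero atoms) in place of a group of 7 heavy atoms (6 carbon, 1 fluorine; one six-membered aromatic ring of carbon only), on a sulfonyl sulfur. Within the data shown here, no measured pair shows this change, so its size is open; a modest rise in this assay, or none beyond the scatter, is expected for compound 4, as a step of a 1.3-fold higher number from compound 3 to compound 4 (0.13 log units; within the scatter). Compound 4 is therefore estimated at 35 mL.min-1.g-1, between 15 mL.min-1.g-1 and 80 mL.min-1.g-1.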

Compound 4, intrinsic clearance in microsomes: > 100 mL.min-1.g-1
Compound 4: no number, only a limit; the forecaster's own chance of this, stated with the estimate: 10%; at least 2.8-fold (0.45 log units) between middle value and limit.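

Exchanging the 4-fluorophenyl on a sulfonyl sulfur for the five-membered aromatic ring with 2 hetero atoms gives in this assay an at least 3.8-fold higher number from compound 3 to compound 4 (0.58 log units; beyond the scatter). This only measured pair at this position shows that the group on the sulfonyl sulfur alone can move the number beyond the scatter while the rest of the molecule stays the same. The true size of the step stays unknown, as the value of compound 4 is a limit and not a number: the limit of > 100 mL.min-1.g-1 in this assay, at which 2 of the 4 values shown sit.

The compounds shown leave open whether the ring itself or the propyl chain on it carries the step. A methyl group in place of that propyl chain, or an unsubstituted phenyl on the sulfonyl sulfur, would bear on this question.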